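The compounds below may be only part of what the source reports. "The series", "measured", "known", "first", "only" and "open" are said of these compounds alone.

Measured compounds:
compound 1, `Cc1c(OC[C@@H](C)COc2ccc(F)c(C(=O)O)c2)ccc(C(=O)CC(C)(C)C)c1O`, 112 nM
compound 2, `Cc1c(OC[C@@H](C)COc2ccc(C(=O)O)cc2F)ccc(C(=O)CC(C)(C)C)c1O`, 222 nM
compound 3, `Cc1c(OC[C@@H](C)COc2ccc(C(=O)O)cc2Cl)ccc(C(=O)CC(C)(C)C)c1O`, 477 nM

In an assay for positive allosteric modulation of metabotropic glutamate receptor 2 (Rattus norvegicus) (a lower number here means that less compound is needed, a higher number that more compound is needed for the effect), compound 3 stands at the highest of the three numbers; the step of a 2.1-fold higher number from compound 2 to compound 3 (0.33 log units; beyond the scatter) is beyond the scatter, as is the larger step of a 4.3-fold higher number from compound 1 to compound 3 (0.63 log units; beyond the scatter), while the step of a 2.0-fold higher number from compound 1 to compound 2 (0.30 log units; within the scatter) lies within it. Compound 4, `Cc1cc(OC[C@H](C)COc2ccc(C(=O)CC(C)(C)C)c(O)c2C)ccc1C(=O)O`, has not been measured in this assay. It differs from compound 3 in one place: 4-carboxy-3-methylphenyl in place of 4-carboxy-2-chlorophenyl on an oxygen on a saturated carbon. Within the data shown here, no measured step swaps a chloro for a methyl, and none moves a substituent to the position the methyl takes here, so the measured steps bear on it only loosely. The closest, a 2.1-fold higher number from compound 2 to compound 3 (0.33 log units; beyond the scatter), shows that exchanging one halogen for another on that ring shifts the number modestly. The carboxy group keeps its place on the ring, as in compound 2 and compound 3. Compound 4 is therefore expected to land near compound 3, perhaps a modestly lower number, with the estimated step of a 1.6-fold lower number from compound 3 to compound 4 (0.20 log units; within the scatter). The estimate for compound 4 is 300 nM, in a range from 100 nM to 1000 nM.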

Compound 4, half-maximal effective concentration: 305 nM
For compound 4 the middle estimate is 1.0-fold (0.01 log units) below the measured one, within the range that was stated.
By their numbers in this assay, from the lowest: compounds 1, 2, 4 and 3 (each within the scatter of the next, the first and the last beyond it).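

In this assay, the methyl-bearing ring of compound 4 does not separate from either halogen-bearing ring that has its carboxy group in the same place: a 1.6-fold lower number from compound 3 to compound 4 (0.19 log units; within the scatter) and a 1.4-fold higher number from compound 2 to compound 4 (0.14 log units; within the scatter) both stay within the scatter, even though compound 2 and compound 3 are printed as just beyond it from each other. Among these compounds, the only step from compound 4 that clears the scatter is to the 3-carboxy-4-fluorophenyl ring, a 2.7-fold higher number from compound 1 to compound 4 (0.44 log units; beyond the scatter), so on this oxygen a methyl serves about as well as fluoro or chloro, though it is not a different ring position for the halogen that was tested. Nothing at hand explains these differences.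

The compounds shown leave open how a methoxy or trifluoromethyl group on this ring would read, or a ring bearing the carboxy group alone. They also leave open a tetrazole in place of the carboxylic acid.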